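Adding a Methoxy Group to a Nitro-Bearing Benzothiazole Enamine

The source may hold more compounds than are shown below. What is called first, only, known or untested is meant among the compounds shown, and "the series" means these compounds.

Three measured compounds share a core and differ at the outer rings. Compound 1 `COc1cc(OC)c2sc(-c3ccc(N/C=C\C(=O)c4ccc(OC)c(O)c4)cc3)nc2c1` in a functional assay on HeLa cells (Homo sapiens) for antiproliferative activity, read by sulforhodamine B assay, with a stated time of 48 h (a lower number here means a stronger inhibitor, a higher number a weaker inhibitor), gives 12100 nM, compound 2 `COc1ccc(C(=O)/C=C\Nc2ccc(-c3nc4cc(OC)c(OC)c(OC)c4s3)cc2)cc1O` gives 14100 nM, and compound 3 `COc1ccc(C(=O)/C=C\Nc2ccc(-c3nc4cc(OC)c(OC)c(OC)c4s3)cc2)cc1[N+](=O)[O-]` gives 11400 nM. The change from compound 1 to compound 2 is methoxy in place of hydrogen on an aromatic carbon, and it made a 1.2-fold higher number from compound 1 to compound 2 (0.07 log units; within the scatter). The change from compound 2 to compound 3 made a 1.2-fold lower number from compound 2 to compound 3 (0.09 log units; within the scatter). The difference between the core of compound 1 and the core of compound 3 is not broken down here.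

Compound 4 `COc1cc(C(=O)/C=C\Nc2ccc(-c3nc4cc(OC)c(OC)c(OC)c4s3)cc2)cc([N+](=O)[O-])c1OC` is not yet measured in this assay. It differs from compound 3 by methoxy in place of hydrogen on an aromatic carbon. This is the same kind of change as that from compound 1 to compound 2, but the surroundings differ: there it sat on a ring that is part of a fused or bridged system of two rings, ortho to two methoxy groups, while here it sits ortho to one methoxy group, meta to a large group and meta to a nitro group. The step from compound 3 to compound 4 is expected to be a 1.1-fold higher number from compound 3 to compound 4 (0.04 log units; within the scatter), because the earlier step was a 1.2-fold higher number from compound 1 to compound 2 (0.07 log units; within the scatter). Compound 4 is thus estimated at 12500 nM.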

Compound 4, half-maximal inhibitory concentration: 7800 nM
Beside the measured number, compound 4's estimate is 1.6-fold (0.20 log units) above it; measured number inside the range.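

In this assay, methoxy in place of hydrogen on an aromatic carbon, ortho to a methoxy group and meta to a nitro group, gave a 1.5-fold lower number from compound 3 to compound 4 (0.16 log units; within the scatter). Set beside the same change made earlier on another core, the two steps cannot be told apart: the same change on two cores in this assay, a 1.2-fold higher number (0.07 log units; within the scatter) from compound 1 to compound 2 and a 1.5-fold lower number (0.16 log units; within the scatter) from compound 3 to compound 4, 1.7-fold (0.23 log units) apart, within the scatter of two such steps. Among the compounds shown here, this shows only that on these two cores the change stayed within the ordinary spread of repeated measurements; it does not show that the change has the same effect on both cores, since steps this small cannot separate a small real effect from no effect, and it says nothing about any other core.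

The compounds shown leave open what a clearly different group would do at this place on the ring, such as an amine, a carboxylic acid or a longer chain in place of the methoxy group. They also leave open whether any such group would give a step large enough to compare between cores.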